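Halogen swap on the thiourea-side ring of compound 2

A few compounds are considered here, and "the series" means these few. Any claim that something is new, unique, unknown or untested is made for them only; others in the source may bear on it.

Two analogues of this diaryl ether thiosemicarbazone series have been measured in a physicochemical assay for lipophilicity, in phosphate buffer, measured as octanol-water partition, with a stated time of 24 h; a lower number here means a more polar compound, a higher number a more lipophilic compound. Compound 1 `Cc1ccc(Oc2ccc(/C=N/NC(=S)Nc3ccc(Cl)cc3)cc2)cc1` gives 5.97, and compound 2 `Fc1ccc(NC(=S)N/N=C/c2ccc(Oc3ccc(F)cc3)cc2)cc1` gives 5.19. Compound 2 stands at the lower of the two numbers, with compound 1 the nearest and higher by a gap beyond the scatter; the two compounds differ at more than one place, so the numbers alone are what these two values show.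

Compound 3 `Fc1ccc(Oc2ccc(/C=N/NC(=S)Nc3ccc(Cl)cc3)cc2)cc1` follows from compound 2 by chloro in place of fluoro on an aromatic carbon. For the measured compounds named here, no measured pair in the set isolates this single change, so the direction rests on the chloro-bearing compound 1 sitting at 5.97 against compound 2 at 5.19. A step upward of moderate size, beyond the scatter, is expected in this assay. For compound 3 the expected partition coefficient is estimated at 5.7, in the range 5.3 to 6.1. The estimated step from compound 2 to compound 3 is a number 0.51 log units higher from compound 2 to compound 3 (beyond the scatter).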

Compound 3, partition coefficient: 5.84
Compound 3: the middle estimate sits 0.14 log units below what was measured; the measured number falls inside the stated range.
By their numbers in this assay, from the lowest: compound 2; then compounds 3 and 1 (each within the scatter of the next).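

In this assay the change of chloro in place of fluoro on an aromatic carbon, para to a large group, now stands alone and gives a number 0.65 log units higher from compound 2 to compound 3 (beyond the scatter) in a pair differing at one place, which compound 1 and compound 2 could not provide. With the chloro kept, fluoro in place of methyl on an aromatic carbon gives a number 0.13 log units lower from compound 1 to compound 3 (within the scatter) and so does not separate these two compounds. No measurement at hand bears on the origin of either step.

The compounds shown leave open how an amine, a carboxylic acid or a methoxy group at this position would compare with the two halogens in this assay on the same core. They also leave open whether chloro in place of fluoro gives a similar step on the other aromatic ring, where only fluoro and methyl appear here.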